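The source may hold more compounds than are shown below. What is called first, only, known or untested is meant among the compounds shown, and "the series" means these compounds.

Measured in a functional assay on L5178Y cells (Mus musculus) for inhibition, read by MTT assay, with a stated time of 24 h; a lower number here means a stronger inhibitor, a higher number a weaker inhibitor:
compound 1 `COc1cccc(/C=N/N=C2\C[C@@H](c3ccc(O)cc3)Oc3cc(OC)cc(O)c32)c1`: >= 11300 nM (a limit)
compound 2 `COc1cc(O)c2c(c1)O[C@H](c1ccc(O)cc1)C/C2=N\Nc1ccccc1`: >= 11300 nM (a limit)

Compound 2 has no exact value in this assay: compound 2 stands at >= 11300 nM, which is a limit and not a number. The two measured compounds share the same position, (the limit of >= 11300 nM in this assay, at which 2 of the 2 values shown sit).

Compound 3 `COc1cc(O)c2c(c1)O[C@H](c1ccc(O)cc1)C/C2=N\Nc1ccc(Br)cn1` departs from compound 2 by one change: 5-bromopyridin-2-yl in place of phenyl on an amine nitrogen. In words, 5-bromopyridin-2-yl stands in place of phenyl on an amine nitrogen. For the measured compounds named here, the only measured step is a step that the two limits leave unreadable from compound 1 to compound 2, and it gives no size to carry over to this change. No shift beyond the scatter can therefore be predicted in either direction, and a result near the same limit is expected. The expected step is a step that the limit leaves unreadable from compound 2 to compound 3. For compound 3 the estimate is 12000 nM, with an expected range from 4000 nM to 30000 nM.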

Compound 3, half-maximal inhibitory concentration: 4300 nM
Beside the measured number, compound 3's estimate is 2.8-fold (0.45 log units) above it; the measured number falls inside the stated range.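

In this assay, 5-bromopyridin-2-yl in place of phenyl on an amine nitrogen gives an at least 2.6-fold lower number from compound 2 to compound 3 (0.41 log units; beyond the scatter), so a change at this position can move the result, which the earlier pair could not show, its step being unreadable. Against the larger group carried by compound 1, the group of compound 3 gives an at least 2.6-fold lower number from compound 1 to compound 3 (0.41 log units; beyond the scatter). Compound 3 is the only one of the three with an exact number, and the other two remain at a limit: the limit of >= 11300 nM in this assay, at which 2 of the 3 values shown sit.

The change brings in the ring nitrogen and the bromine together, and the compounds shown leave open how the step divides between them, a question that plain pyridin-2-yl or a bromophenyl group would address. From the compounds shown here alone, the full size of the step also stays open, and so does whether chlorine or a methoxy group in place of bromine would give a similar result.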